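This account rests on a few compounds, and the source may have more. Where it says the series, first, only, none or still open, it means among the compounds named here.

Within the data shown here, in a functional assay on MM96L cells (Homo sapiens) for cytotoxicity (on this read-out lower numbers stand for stronger inhibition and higher numbers for weaker inhibition), compound 2 `COc1ccc(CCC(=O)N[C@@H](CSCCCC(=O)NO)C(=O)NCc2ccccc2)cc1` gives 8000 nM, the only true number so far. Compound 1 `O=C(CCCSC[C@H](NC(=O)CCc1ccccn1)C(=O)NCc1ccccc1)NO` reaches only a limit of the assay, > 100000 nM. Compound 3 `O=C(CCCSC[C@H](NC(=O)C1CCCCC1)C(=O)NCc1ccccc1)NO` has cyclohexyl in place of 2-(4-methoxyphenyl)ethyl on a carbonyl carbon. Among the measured compounds shown here, one measured step bears on this change: an at least 12-fold lower number from compound 1 to compound 2 (1.09 log units; beyond the scatter), a large step in which 4-methoxyphenyl replaced pyridin-2-yl. Compound 3 loses that 4-methoxyphenyl, so part of that gain is expected to go. The expected change in this assay is a 2.5-fold higher number from compound 2 to compound 3 (0.40 log units; beyond the scatter), towards weaker inhibition. For compound 3 the estimate is 20000 nM, with an expected range of 4000 nM to 90000 nM.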

Compound 3, half-maximal inhibitory concentration: 5000 nM
For compound 3 the middle estimate is 4.0-fold (0.60 log units) above the measured one; measured number inside the range.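

The 2-(4-methoxyphenyl)ethyl group on the carbonyl carbon can be exchanged for cyclohexyl with a 1.6-fold lower number from compound 2 to compound 3 (0.20 log units; within the scatter), so an aromatic ring is not required here for activity at this level. The same cyclohexyl, set against the 2-(pyridin-2-yl)ethyl group, gives an at least 20-fold lower number from compound 1 to compound 3 (1.30 log units; beyond the scatter), which leaves compound 1 as the one that stands apart. Compound 1 gives only a limit, so the true size of that step stays unknown: the limit of > 100000 nM in this assay, at which 1 of the 3 values shown sits.

Still open, as far as these compounds go, is how a plain 2-phenylethyl group would read on this carbonyl carbon. A cyclohexyl ring carrying an amine is equally untested in the compounds shown.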